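Halogenated phenyl series: from compound 3 to compound 4

The compounds below may be only part of what the source reports. "The series", "measured", "known", "first", "only" and "open" are said of these compounds alone.

In a functional assay on HL-60 cells (Homo sapiens) for antiproliferative activity, with a stated time of 72 h (a higher number here means a weaker inhibitor, a lower number a stronger inhibitor), three compounds with a shared core differ only in the halogenated phenyl group on a saturated chain carbon bound to a nitrogen on an aromatic ring. Compound 1 `OC[C@H]1O[C@@H](n2cnc3c(NCc4ccc(F)cc4)ncnc32)[C@H](O)[C@@H]1O` gives 1200 nM, compound 2 `OC[C@H]1O[C@@H](n2cnc3c(NCc4ccccc4Br)ncnc32)[C@H](O)[C@@H]1O` gives 6600 nM and compound 3 `OC[C@H]1O[C@@H](n2cnc3c(NCc4ccc(Cl)c(Cl)c4)ncnc32)[C@H](O)[C@@H]1O` gives 2000 nM. Compound 3 cannot be separated from compound 1, as a 1.7-fold higher number from compound 1 to compound 3 (0.22 log units; within the scatter) stays within the scatter, whereas a 3.3-fold lower number from compound 2 to compound 3 (0.52 log units; beyond the scatter) lies beyond it.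

Compound 4 `OC[C@H]1O[C@@H](n2cnc3c(NCc4c(F)ccc(F)c4F)ncnc32)[C@H](O)[C@@H]1O` carries 2,3,6-trifluorophenyl in place of 3,4-dichlorophenyl on a saturated chain carbon bound to a nitrogen on an aromatic ring. The entering group shares fluorine with the 4-fluorophenyl of compound 1 and a halogen at its 2 position with the 2-bromophenyl of compound 2. The measured precedents therefore pull in different directions. For the measured compounds named here, the only clear penalty is a 5.5-fold higher number from compound 1 to compound 2 (0.74 log units; beyond the scatter), which is modest, and no measured compound carries three halogens. In this assay, no step beyond the scatter is expected, with a slight lean towards a higher number resting on compound 2 at 6600 nM. The expected change is a 1.5-fold higher number from compound 3 to compound 4 (0.18 log units; within the scatter). For compound 4 the estimated value is 3000 nM, with an expected range of 1000 nM to 9000 nM.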

Compound 4, half-maximal inhibitory concentration: 13000 nM
Compound 4: the middle estimate sits 4.3-fold (0.64 log units) below what was measured; measured number outside the range, above it.
By their numbers in this assay, from the lowest: compounds 1 and 3 (each within the scatter of the next); then compounds 2 and 4 (each within the scatter of the next).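

In this assay, the place on a saturated chain carbon bound to a nitrogen on an aromatic ring proves more sensitive to the halogen pattern than the first three compounds showed: a 6.5-fold higher number from compound 3 to compound 4 (0.81 log units; beyond the scatter) and an 11-fold higher number from compound 1 to compound 4 (1.03 log units; beyond the scatter) set the 2,3,6-trifluorophenyl group clearly apart from both 3,4-dichlorophenyl and 4-fluorophenyl. With a 2.0-fold higher number from compound 2 to compound 4 (0.29 log units; within the scatter) the 2,3,6-trifluorophenyl and 2-bromophenyl compounds cannot be separated, so these two now form a weaker pair against compounds 1 and 3, and none of the four compounds goes against that split; fluorine as the only halogen does not by itself keep the number low, as compounds 1 and 4 both carry only fluorine yet stand far apart. No measurement available here bears on the reason for these steps.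

With four halogenated groups, the split cannot be assigned to any one ring position or to the number of halogens, since compounds 2 and 4 differ in both. As far as these compounds go, how an unsubstituted phenyl group, a methoxy group on the ring or a longer chain to the ring would compare remains open.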